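The source may report more compounds than this note shows. Statements on the series, on what has been measured and on what is new or still open speak of the compounds shown alone.

Compounds measured:
compound 1 `COc1ncc(-c2nc(C(F)(F)F)sc2N2CCN(C(=O)Cn3cnc4cccnc43)[C@H](C)C2)cn1` — 3.8 nM
compound 2 `CCOc1ncc(-c2nc(C(F)(F)F)sc2N2CCN(C(=O)Cn3nc(C)nc3C)[C@H](C)C2)cn1` — 7 nM
compound 3 `COc1ncc(-c2nc(C(F)(F)F)sc2N2CCN(C(=O)Cn3nc(C)nc3C)[C@H](C)C2)cn1` — 25 nM

All three were run in a functional assay on CHO-K1 cells for antagonist activity at C-X-C chemokine receptor type 3 (Homo sapiens), read by FLIPR, with a stated time of 10 min; on this read-out higher numbers stand for weaker inhibition and lower numbers for stronger inhibition. Compound 3 gives the highest number of the three; the two steps leading up to it are a 3.6-fold higher number from compound 2 to compound 3 (0.55 log units; beyond the scatter) and a 6.6-fold higher number from compound 1 to compound 3 (0.82 log units; beyond the scatter). Compound 4 `Cc1nc(C)n(CC(=O)N2CCN(c3sc(C(F)(F)F)nc3-c3cnc(OC4CCC4)nc3)C[C@H]2C)n1` differs from compound 3 by cyclobutyl in place of methyl on an oxygen on an aromatic ring. Within the data shown here, the one step that bears on this is a 3.6-fold higher number from compound 2 to compound 3 (0.55 log units; beyond the scatter), where hydrogen in place of methyl on the saturated chain carbon bound to the ring oxygen raised the number; compound 4 goes the other way and further, from methoxy to cyclobutyloxy. Extension past a single added carbon has no measured precedent here, so the size is uncertain. Compound 4 is expected to move by a 3.1-fold lower number from compound 3 to compound 4 (0.49 log units; beyond the scatter), toward a lower number. The estimate for compound 4 is 8 nM, with a range of 2.5 nM to 25 nM.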

Compound 4, half-maximal inhibitory concentration: 4 nM
For compound 4 the middle estimate is 2.0-fold (0.30 log units) above the measured one; the range from low to high includes it.
By their numbers in this assay, from the lowest: compounds 1, 4 and 2 (each within the scatter of the next); then compound 3.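

On the oxygen on the aromatic ring, the step to a larger alkyl group does not stop at ethyl: cyclobutyl in place of methyl gives a 6.3-fold lower number from compound 3 to compound 4 (0.80 log units; beyond the scatter) and brings a ring to this position. Cyclobutyl in place of ethyl gives a 1.8-fold lower number from compound 2 to compound 4 (0.24 log units; within the scatter), so these two groups are not separated here. No available measurement explains either step.

Open, as far as these compounds go, is whether a longer chain, cyclohexyl or an amine-bearing group on this oxygen holds the number down. Also open, from the compounds shown here alone, is whether cyclobutyloxy behaves alike with the amide side chain of compound 1.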